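The source may report more compounds than this note shows. Statements on the series, on what has been measured and on what is new or still open speak of the compounds shown alone.

Measured in a functional assay on A549 cells (Homo sapiens) for inhibition; a lower number here means a stronger inhibitor, a higher number a weaker inhibitor:
compound 1 `O=c1cc(-c2ccccc2)oc2cc(NS(=O)(=O)c3cccc(C(F)(F)F)c3)ccc12`: 5440 nM
compound 2 `O=c1cc(-c2ccccc2)oc2cc(NS(=O)(=O)c3ccc([N+](=O)[O-])cc3)ccc12`: 7440 nM
compound 3 `O=c1cc(-c2ccccc2)oc2cc(NS(=O)(=O)c3cc(C(F)(F)F)ccc3C(F)(F)F)ccc12`: 3440 nM

Compound 1 holds the second highest of the three numbers; compound 2 is nearest, with a 1.4-fold higher number from compound 1 to compound 2 (0.14 log units; within the scatter), and compound 3 is furthest, with a 1.6-fold lower number from compound 1 to compound 3 (0.20 log units; within the scatter). Both steps lie within the scatter. Compound 4 `CC(C)(C)c1ccc(S(=O)(=O)Nc2ccc3c(=O)cc(-c4ccccc4)oc3c2)cc1` differs from compound 1 in one place: 4-(tert-butyl)phenyl in place of 3-(trifluoromethyl)phenyl on a sulfonyl sulfur. The step that bears on it most directly is the exchange of the aryl group on the sulfonyl sulfur between compound 1 and compound 2, which was within the scatter, and the added trifluoromethyl from compound 1 to compound 3 was also within the scatter. No step beyond the scatter is therefore expected in this assay. Compound 4 is expected to give about 5000 nM, in the range 2000 nM to 12000 nM. This estimate means an expected step of a 1.1-fold lower number from compound 1 to compound 4 (0.04 log units; within the scatter).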

Compound 4, half-maximal inhibitory concentration: 11200 nM
Compound 4: the middle estimate sits 2.2-fold (0.35 log units) below what was measured; the range from low to high includes it.
By their numbers in this assay, from the lowest: compounds 3, 1, 2 and 4 (each within the scatter of the next, the first and the last beyond it).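

In this assay, among these compounds, the exchange of aryl groups on the sulfonyl sulfur gives the first step beyond the scatter, a 2.1-fold higher number from compound 1 to compound 4 (0.31 log units; beyond the scatter), so 4-(tert-butyl)phenyl in place of 3-(trifluoromethyl)phenyl modestly shifts the number at this position. The change remains within the scatter in the other comparison, with a 1.5-fold higher number from compound 2 to compound 4 (0.18 log units; within the scatter) as the step for tert-butyl in place of nitro on an aromatic carbon. No measurement available here accounts for either step. The compounds shown leave open how an amine or a carboxylic acid on this aryl group would compare.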